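From 2-methylphenyl to 4-methoxyphenyl on a sulfonyl sulfur

This account rests on a few compounds, and the source may have more. Where it says the series, first, only, none or still open, it means among the compounds named here.

compound 1 `COc1ccc(S(=O)(=O)NC(C2=CC(=O)c3c(O)ccc(O)c3C2=O)C(C)C)cc1`: 8950 nM
compound 2 `Cc1ccccc1S(=O)(=O)NC(C)C1=CC(=O)c2c(O)ccc(O)c2C1=O`: 4490 nM

In a functional assay on HeLa cells (Homo sapiens) for cytotoxicity, read by sulforhodamine B assay (on this read-out lower numbers stand for stronger inhibition and higher numbers for weaker inhibition), compound 2 gives 4490 nM and compound 1 gives 8950 nM on the same read-out, and these two values lie within the usual scatter of each other. Compound 3 `COc1ccc(S(=O)(=O)NC(C)C2=CC(=O)c3c(O)ccc(O)c3C2=O)cc1` has not yet been measured. It differs from compound 2 in one place, with 4-methoxyphenyl in place of 2-methylphenyl on a sulfonyl sulfur as the whole of the change.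

Among the compounds with values here, no measured pair shows this change alone. Compound 3 shares 4-methoxyphenyl with compound 1, which differs from it elsewhere and gives 8950 nM in this assay as its result, within the scatter of the value for compound 2. The two values therefore offer no sign of a large move, and the step of a 1.2-fold higher number from compound 2 to compound 3 (0.09 log units; within the scatter) is expected to stay within the scatter, with no direction favoured. For compound 3 the estimated value is 5500 nM with an expected range from 2200 nM to 13000 nM in this assay.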

Compound 3, half-maximal inhibitory concentration: 3760 nM
Beside the measured number, compound 3's estimate is 1.5-fold (0.17 log units) above it, within the range that was stated.
By their numbers in this assay, from the lowest: compounds 3, 2 and 1 (each within the scatter of the next, the first and the last beyond it).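

In this assay the change from 2-methylphenyl to 4-methoxyphenyl on a sulfonyl sulfur can now be read on its own, and it is a 1.2-fold lower number from compound 2 to compound 3 (0.08 log units; within the scatter); with methyl on the saturated chain carbon, these two groups on the sulfonyl sulfur cannot be told apart. Compound 3 also supplies the first step among these compounds that lies beyond the scatter, a modest one: with 4-methoxyphenyl held on the sulfonyl sulfur, methyl in place of isopropyl on a saturated chain carbon bound to a double-bonded ring carbon and a sulfonamide nitrogen gives a 2.4-fold lower number from compound 1 to compound 3 (0.38 log units; beyond the scatter). Nothing measured here bears on the cause of either step.

As far as these compounds go, it remains open whether a phenyl group carrying an amine or a carboxylic acid, or a plain alkyl chain, on the sulfonyl sulfur would also stay within the scatter of compound 3. Also open, from the compounds shown here alone, are how a longer chain in place of methyl on the saturated chain carbon would read, and whether the step seen with 4-methoxyphenyl would hold with 2-methylphenyl on the sulfonyl sulfur.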